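The source may report more compounds than this note shows. Statements on the series, on what has been measured and on what is new or still open speak of the compounds shown alone.

Measured in a functional assay on HL-60 cells (Homo sapiens) for inhibition, read by MTT assay; on this read-out higher numbers stand for weaker inhibition and lower numbers for stronger inhibition:
- Compound 1 `O=C(/C=C/c1cc(O)c(O)c([N+](=O)[O-])c1)OCCc1ccccc1`: "not determined" (no result reported)
- Compound 2 `CC1(C)C2CCC1(C)C(OC(=O)/C=C/c1ccc(O)c(O)c1)C2`: 3350 nM

From the compounds shown here alone, compound 1 has no number to stand on: in this assay compound 1 is reported as "not determined" (no result reported), so its place relative to compound 2 is unknown. The next compound, compound 3 `O=C(/C=C/c1cc(O)c(O)c(Br)c1)OCCc1ccccc1`, keeps the rest of compound 1 and changes one group: bromo in place of nitro on an aromatic carbon, ortho to a hydroxy group (bromo in place of nitro on an aromatic carbon). With no starting value, the size and direction of this step in this assay cannot be read from the data. For the measured compounds named here, the only anchor is compound 2 at 3350 nM, and a result in that region, with no clear gap beyond the usual scatter in either direction, is the expectation. Compound 3 is expected at about 4000 nM, with an estimated range of 1200 nM to 15000 nM.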

Compound 3, half-maximal inhibitory concentration: 8490 nM
The estimate for compound 3 lay 2.1-fold (0.33 log units) below the measured number; the measured number falls inside the stated range.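

For the compounds shown here, compound 1 carries no number in this assay, so no step from compound 1 to compound 3 can be read. The compounds shown leave open how bromo compares with nitro on the shared core. No measured evidence bears on this result.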